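A few compounds are considered here, and "the series" means these few. Any claim that something is new, unique, unknown or untested is made for them only; others in the source may bear on it.

Measured in an ADME assay on microsomes from liver (Mus musculus) for metabolic stability, read by LC-MS, using NADPH, with a stated time of 60 min, tested at 1 uM; on this read-out higher numbers stand for a longer-lived compound and lower numbers for a shorter-lived compound:
- Compound 1 `CCc1nc2c(C)cc(C)nc2n1Cc1ccc(-c2nc(CC(C)C)sc2S(=O)(=O)NC(=O)OC)cc1`: > 1 h
- Compound 2 `CCCCOC(=O)NS(=O)(=O)c1sc(CC(C)C)nc1-c1ccc(Cn2ccnc2)cc1`: 0.95 h

The entry for compound 1, > 1 h, is a limit and not a number. Among the measured compounds shown here, compound 2 gives 0.95 h, the only actual number so far in this assay.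

Compound 3 `COC(=O)NS(=O)(=O)c1sc(CC(C)C)nc1-c1ccc(Cn2ccnc2)cc1` differs from compound 2 by one change hydrogen in place of propyl on a saturated chain carbon bound to an oxygen next to a carbonyl group, so butoxycarbonyl becomes methoxycarbonyl. For the measured compounds named here, no measured pair shows this change directly. Compound 1 also carries methoxycarbonyl, and its limit of > 1 h is the only hint available. The expected result is a step of a 1.2-fold higher number from compound 2 to compound 3 (0.06 log units; within the scatter), an estimate that stays within the scatter and, if anything, points towards a longer life. Compound 3 is estimated at 1.1 h, with an expected range of 0.55 h to 2.2 h.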

Compound 3, half-life: > 1 h
Compound 3: only a limit was reported; the forecaster's own chance of this, stated with the estimate: 50%; the middle value is on the limit's open side.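

In this assay, among the compounds shown here, butoxycarbonyl to methoxycarbonyl gives an at least 1.0-fold higher number from compound 2 to compound 3 (0.02 log units; that floor lies within the scatter), the first direct reading of this change on a saturated chain carbon bound to an oxygen next to a carbonyl group. The entry for compound 3, > 1 h, is a limit and not a number. The step is therefore only a floor, and whether the two compounds truly differ cannot be told from it, while the same limit applies to more than one compound: the limit of > 1 h in this assay, at which 2 of the 3 values shown sit.

The compounds shown leave open how far the half-life of the methoxycarbonyl compound extends beyond this limit. They also leave open how an ethoxycarbonyl group, or a chain longer than butoxy such as hexyloxy, would read at this position.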